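The compounds below may be only part of what the source reports. "The series", "measured", "known", "first", "only" and "open" are said of these compounds alone.

Compound 1 `CCOc1ccc(-c2nn3cc(-c4cccc(N)c4)nc3s2)cc1` carries a free amine on one of its aromatic rings. In a functional assay on CCRF-CEM cells (Homo sapiens) for inhibition, read by cell counting, with a stated time of 3 days (a higher number here means a weaker inhibitor, a lower number a stronger inhibitor), compound 1 gives > 250000 nM, and this is a limit of the assay rather than a number. Compound 1 therefore stands at the limit of > 250000 nM in this assay, at which 1 of the 3 values shown sits. Compound 2 `C=C(Br)C(=O)Nc1cccc(-c2cn3nc(-c4ccc(OCC)cc4)sc3n2)c1` differs from compound 1 only by a (1-bromoethenyl)carbonyl placed on that nitrogen, and in this assay compound 2 gives 1400 nM. Among the measured compounds shown here, the step of an at least 170-fold lower number from compound 1 to compound 2 (2.25 log units; beyond the scatter) is the only single-place step that has been measured, and it concerns the nitrogen alone. For the measured compounds named here, compound 3 `C=C(Br)C(=O)Nc1cccc(-c2cn3c(-c4ccc(OC)cc4)csc3n2)c1` also carries the (1-bromoethenyl)carbonyl, and in this assay compound 3 gives 500 nM; no single-place step joins it to compound 1 or compound 2.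

Compound 4 `Nc1cccc(-c2cn3nc(-c4ccc(F)cc4)sc3n2)c1` has not yet been measured. It differs from compound 1 by fluoro in place of ethoxy on an aromatic carbon, while the amine stays free as in compound 1. Going by the values given here, no measured step touches the group at that place, so none bears directly on this change; the one measured step of an at least 170-fold lower number from compound 1 to compound 2 (2.25 log units; beyond the scatter) concerns the nitrogen instead. With the nitrogen unchanged, no step beyond the scatter is expected, and compound 4 is expected to remain at the limit. The estimate for compound 4 is 300000 nM, with a range from 100000 nM to 1000000 nM. The expected step is a step that the limit leaves unreadable from compound 1 to compound 4.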

Compound 4, half-maximal inhibitory concentration: >= 250000 nM
Compound 4: only a limit was reported; the forecaster's own chance of this, stated with the estimate: 85%; the middle value does not contradict the limit.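

In this assay compound 4 gives >= 250000 nM, which is a limit of the assay and not a number. Compound 1 also stands at a limit, and the step between compound 1 and compound 4 cannot be read. The compounds shown leave open how fluoro and ethoxy compare when the nitrogen carries the (1-bromoethenyl)carbonyl.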